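Replacing the benzylamino link with a phenoxy link

The compounds below may be only part of what the source reports. "The series", "measured", "known", "first", "only" and "open" are said of these compounds alone.

Compound 1 `Nc1cc(N)c2nc(-c3ccccc3)c(NCc3ccc(F)cc3)nc2c1` — 29500 nM
Compound 2 `COc1ccc(CNc2nc3cc(N)cc(N)c3nc2-c2ccccc2)cc1` — 29500 nM

In a functional assay on UACC-62 cells (Homo sapiens) for inhibition, read by sulforhodamine B assay, with a stated time of 48 h (on this read-out higher numbers stand for weaker inhibition of growth and lower numbers for stronger inhibition of growth), compound 1 gives 29500 nM, level with compound 2 within the scatter. Among the measured compounds shown here, the one measured step, no change at the digits printed from compound 1 to compound 2 (within the scatter), changes the substituent on the pendant ring and leaves the link to the core untouched. Compound 3 `Nc1cc(N)c2nc(-c3ccccc3)c(Oc3ccc(F)cc3)nc2c1` differs from compound 1 by 4-fluorophenoxy in place of (4-fluorobenzyl)amino on an aromatic carbon. For the measured compounds named here, no measured step bears on this exchange of the link, so the data give no direction for it. The step of no change at the digits printed from compound 1 to compound 3 (within the scatter) is expected to stay within the scatter. Compound 3 is estimated at 29500 nM, between 8000 nM and 90000 nM.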

Compound 3, concentration for total growth inhibition: 33100 nM
Estimate against measurement, compound 3: 1.1-fold (0.05 log units) below; the measured number falls inside the stated range.
By their numbers in this assay, from the lowest: compounds 1, 2 and 3 (each within the scatter of the next).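

In this assay, 4-fluorophenoxy in place of (4-fluorobenzyl)amino gives a 1.1-fold higher number from compound 1 to compound 3 (0.05 log units; within the scatter). The earlier step changed only the substituent on the pendant ring, whereas this one shows that the link to the core can also be exchanged with the result staying within the scatter. No independent measurement offers an explanation for this result. The compounds shown leave open whether a thioether link or an amide link at this position would move the number, and whether a carboxylic acid on the pendant ring would do so.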